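This account rests on a few compounds, and the source may have more. Where it says the series, first, only, none or still open, it means among the compounds named here.

Working notes on the series.

Of the compounds shown here, three have been measured in an assay on SH-EP1 cells for displacement of a labelled ligand from Neuronal acetylcholine receptor; alpha4/beta2 (Homo sapiens), read by scintillation counting; a higher number here means a weaker inhibitor, a lower number a stronger inhibitor. Compound 1 `O=C(C1CC1)N1CC2CC1CN2` gives 2800 nM. Compound 2 `O=C(C1CCCC1)N1CC2CC(C1)N2`, which carries a different core and a five-membered ring on the carbonyl carbon, gives 160 nM. Compound 3 `O=C([C@H]1C[C@H]1F)N1CC2CC(C1)N2` gives 1.1 nM. Compound 3 therefore stands at the lowest number of the three: its gap to compound 2 is beyond the scatter, and its gap to compound 1 is larger still. No pair among these differs in a single place, so no single step can be separated out; the values only show that compound 3 sits far below the other two.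

Compound 4 `C[C@H]1C[C@H]1C(=O)N1CC2CC(C1)N2` has not been measured. It differs from compound 3 in one place: 2-methylcyclopropyl in place of 2-fluorocyclopropyl on a carbonyl carbon. The core and the amide linkage are unchanged; the substituent on the three-membered ring goes from fluorine to a methyl group, with the same count of heavy atoms and the same two defined stereocentres.

Going by the values given here, no measured pair speaks to this exchange directly. Given that compound 3 shows the lowest value in this assay at 1.1 nM, the step from compound 3 to compound 4 is expected to move the number upward, by a 7.3-fold higher number from compound 3 to compound 4 (0.86 log units; beyond the scatter), beyond the scatter but modest. Compound 4 is thus estimated at 8 nM, within a range from 2 nM to 40 nM.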

Compound 4, inhibition constant: 7 nM
For compound 4 the middle estimate is 1.1-fold (0.06 log units) above the measured one; the range from low to high includes it.
By their numbers in this assay, from the lowest: compound 3; then compound 4; then compound 2; then compound 1.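

Going by these compounds alone, this is the first comparison that differs in one place: in this assay, 2-methylcyclopropyl in place of 2-fluorocyclopropyl on a carbonyl carbon gives a 6.4-fold higher number from compound 3 to compound 4 (0.80 log units; beyond the scatter), a modest step that lies beyond the scatter. The number at this position therefore responds to fluorine giving way to a methyl group, even with the heavy-atom count, the three-membered ring and the two defined stereocentres all unchanged, yet compound 4 still reads 7 nM, so in this pair a low number does not depend on the fluorine alone. The data shown offer no explanation for the direction or size of this step.

Still open, as far as these compounds go, is how the three-membered ring would read on the shared core with no substituent at all, or with a chlorine, hydroxymethyl or trifluoromethyl group in place of the fluorine or methyl, and how the opposite arrangement at the two stereocentres would read. Within the data shown here, only one pair speaks to this exchange, so it also remains open whether a step of similar size would appear on the core of compound 1.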